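A formyl group gives way to hydroxymethyl

The compounds below may be only part of what the source reports. "The series", "measured", "known", "first", "only" and "open" are said of these compounds alone.

In an ADME assay on HEK293 cells (Homo sapiens) for cytotoxicity, with a stated time of 72 h (on this read-out lower numbers stand for an effect already at smaller amounts and higher numbers for an effect only at larger amounts of compound), compound 1 (`C=C[C@@](C)(/C=C/c1ccc(OCc2ccccc2)cc1)CCC=C(C)C`) gives > 36600 nM as its reading, which is a limit of the assay and not a number. Compound 2 (`C=C[C@@](C)(/C=C/c1ccc(O)cc1)CCC=O`) gives > 36600 nM as its reading, and that too is only a limit. Compound 2 therefore offers no exact number to build on, and the record so far is short (the limit of > 36600 nM in this assay, at which 2 of the 2 values shown sit).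

Compound 3 (`C=C[C@@](C)(/C=C/c1ccc(O)cc1)CCCO`) has not yet been measured. Its difference from compound 2 is small (hydroxymethyl in place of formyl on a saturated chain carbon, three bonds along the chain from two double-bonded chain carbons): hydroxymethyl in place of formyl on a saturated chain carbon, three bonds along the chain from two double-bonded chain carbons. Among the measured compounds shown here, no pair of measured compounds shows what such a swap does in this assay so no direction can be named, and the expectation is no shift beyond the usual scatter. This expectation rests on compound 2 and its reading of > 36600 nM as a limit. The estimated step that the limit leaves unreadable from compound 2 to compound 3 is expected to stay within that scatter, and another limit reading is the likeliest outcome. For compound 3 the estimated value is 45000 nM with 20000 nM to 90000 nM as its expected range.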

Compound 3, half-maximal effective concentration: > 36600 nM
Compound 3 ended at the assay's limit (the forecaster's own chance of this, stated with the estimate: 85%); the middle value is on the limit's open side.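

Among the compounds shown here, compound 2 and compound 3 both read as limits and not as numbers in this assay, so no step from formyl to hydroxymethyl can be read between them. The record stands at: the limit of > 36600 nM in this assay, at which 3 of the 3 values shown sit.

The compounds shown leave open at what concentration, if any, an effect on these cells would appear, and whether formyl and hydroxymethyl would then differ.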